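A few compounds are considered here, and "the series" means these few. Any claim that something is new, unique, unknown or untested is made for them only; others in the source may bear on it.

Measured so far in a functional assay on MDA-MB-231 cells (Homo sapiens) for inhibition, read by sulforhodamine B assay, tested at 10 uM; a lower number here means less inhibition, a higher number more inhibition at the concentration tested (going by the name of the read-out):
- compound 1, `CC(=O)N1N=C(c2ccc(N3CCN(C)CC3)cc2)CC1c1ccc(N(C)C)cc1`, gives -1%
- compound 2, `CC(=O)N1N=C(c2ccc(-n3ccnc3)cc2)CC1c1ccc(N(C)C)cc1`, gives 5%

For the measured compounds named here, compound 2 stands within the scatter of compound 1, as the only step measured, a number 6 percentage points higher from compound 1 to compound 2 (within the scatter), shows; both values sit near zero inhibition. Compound 3, `CN(C)c1ccc(C2CC(c3ccc(-n4ccnc4)cc3)=NN2S(=O)(=O)c2ccc(C#N)cc2)cc1`, differs from compound 2 by (4-cyanophenyl)sulfonyl in place of acetyl on an amine nitrogen in a ring. Going by the values given here, no measured step touches this position, so the step gives no guide to the size or direction of the change. The expectation for compound 3 therefore rests on the near-zero values of compound 1 and compound 2 alone, with a wide range: the expected step is a number 10 percentage points higher from compound 2 to compound 3 (within the scatter), giving an estimate of 15% between -10% and 45%.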

Compound 3, a percentage reported as inhibition, at one concentration (the size of the read-out at that concentration, not a potency): 7.1%
Compound 3: middle estimate off by 7.9 percentage points, on the high side; the range from low to high includes it.
By their numbers in this assay, from the lowest: compounds 1, 2 and 3 (each within the scatter of the next).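

In this assay, for the compounds shown here, the first measured change at this position, on the amine nitrogen in a ring, puts (4-cyanophenyl)sulfonyl, with 11 heavy atoms, in place of acetyl, with 3 (a number 2.1 percentage points higher from compound 2 to compound 3 (within the scatter)). In this one pair, a far larger group at this position leaves the result within the scatter, still close to zero inhibition. Nothing measured here offers an explanation for this result.

Going by these compounds, whether a chain ending in an amine or a carboxylic acid would shift the number at this position remains open. So does the effect of (4-cyanophenyl)sulfonyl alongside 4-methylpiperazin-1-yl instead of 1H-imidazol-1-yl.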